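Halogen swap on the aryl amine of the shared core

A few compounds are considered here, and "the series" means these few. Any claim that something is new, unique, unknown or untested is made for them only; others in the source may bear on it.

Compound 2 `C=CC(=O)Nc1cccc(NC(=O)CSc2nc(Nc3ccc(Br)cc3)c3ccccc3n2)c1` gives the lower of the two numbers recorded so far in a functional assay on MDA-MB-231 cells (Homo sapiens) for inhibition, read by MTT assay, with a stated time of 72 h (on this read-out higher numbers stand for weaker inhibition and lower numbers for stronger inhibition), at 17300 nM, with compound 1 `C=CC(=O)Nc1cccc(NC(=O)CSc2nc(Nc3ccccc3F)c3ccccc3n2)c1` close by at 18700 nM. Going by the values given here, the one step that joins them, a 1.1-fold lower number from compound 1 to compound 2 (0.03 log units; within the scatter), shows that exchanging one halogenated phenyl on the nitrogen on the aromatic ring for another left the read-out essentially unchanged.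

Compound 3 `C=CC(=O)Nc1cccc(NC(=O)CSc2nc(Nc3ccc(F)c(Cl)c3)c3ccccc3n2)c1` continues in the same vein: the difference from compound 2 is 3-chloro-4-fluorophenyl in place of 4-bromophenyl on a nitrogen on an aromatic ring. Among the compounds with values here, the only measured step that bears on it is the aryl exchange from compound 1 to compound 2, which stayed within the scatter. A further change of the halogen pattern on that phenyl ring therefore gives no grounds to expect a step in this assay beyond the scatter in either direction.

On that basis compound 3 is expected to give about 17000 nM, somewhere between 8000 nM and 36000 nM. The expected step from compound 2 to compound 3 is a 1.0-fold lower number from compound 2 to compound 3 (0.01 log units; within the scatter), that is, essentially flat.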

Compound 3, half-maximal inhibitory concentration: 10600 nM
Compound 3: middle estimate off by 1.6-fold (0.21 log units), on the high side; the range from low to high includes it.
By their numbers in this assay, from the lowest: compounds 3, 2 and 1 (each within the scatter of the next).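

The third group on this nitrogen on an aromatic ring carries two halogens rather than one, and in this assay the exchange of 4-bromophenyl for 3-chloro-4-fluorophenyl gives a 1.6-fold lower number from compound 2 to compound 3 (0.21 log units; within the scatter) and the exchange of 2-fluorophenyl for the same group gives a 1.8-fold lower number from compound 1 to compound 3 (0.25 log units; within the scatter). Going by these compounds alone, the position has thus taken three different halogen patterns, and no pair among compound 1, compound 2 and compound 3 stands apart beyond the scatter, so within these compounds neither the kind of halogen nor a second halogen on the phenyl ring separates the read-outs. No measurement at hand accounts for the size of these steps.

Going by these compounds, all three groups on this nitrogen are halogenated phenyl rings, so it remains open whether a phenyl ring bearing a methoxy group or a dimethylamino group, or an unsubstituted phenyl, would read any differently. The rest of the structure is the same in all three compounds, which leaves open whether a change elsewhere, such as a longer chain in place of the link to the sulfur, would produce a step beyond the scatter.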